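A few compounds are considered here, and "the series" means these few. Any claim that something is new, unique, unknown or untested is made for them only; others in the source may bear on it.

Compound 1 `COc1ccc(NC2=CC(=O)c3c(nc4n3[C@H]3OC[C@@H](O)[C@H]3OC4)C2=O)cc1`: in a functional assay on HeLa cells (Homo sapiens) for inhibition, read by sulforhodamine B assay (on this read-out higher numbers stand for weaker inhibition and lower numbers for stronger inhibition), compound 1 gives > 8000 nM, which is a limit of the assay.
Compound 2 `COc1ccccc1NC1=CC(=O)c2c(nc3n2[C@H]2OC[C@@H](O)[C@H]2OC3)C1=O`: in this assay compound 2 gives 7460 nM.
Compound 3 `O=C1C(N2CCCC2)=CC(=O)c2c1nc1n2[C@H]2OC[C@@H](O)[C@H]2OC1`: in this assay compound 3 gives > 16000 nM, again only a limit.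

Compound 3 thus stands at a limit of this assay, as does compound 1, while compound 2 alone has a number. Compound 4 `O=C1C(Nc2ccc(I)cc2)=CC(=O)c2c1nc1n2[C@H]2OC[C@@H](O)[C@H]2OC1` carries (4-iodophenyl)amino in place of pyrrolidin-1-yl on a double-bonded ring carbon. The step of an at least 2.1-fold higher number from compound 2 to compound 3 (0.33 log units; beyond the scatter) ran the opposite way, so reversing it points toward a lower number; the step that the two limits leave unreadable from compound 1 to compound 3 gives no size, and compounds 1 and 2 remain weak as well. Compound 4 is therefore expected to show a modest drop, an at least 2.0-fold lower number from compound 3 to compound 4 (0.30 log units; that floor lies within the scatter). The estimate for compound 4 is 8000 nM, expected to fall between 3000 nM and 20000 nM.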

Compound 4, half-maximal inhibitory concentration: 4010 nM
The estimate for compound 4 lay 2.0-fold (0.30 log units) above the measured number; low and high end bracket the measured number.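

Putting (4-iodophenyl)amino in place of pyrrolidin-1-yl on the double-bonded ring carbon gives an at least 3.9-fold lower number from compound 3 to compound 4 (0.60 log units; beyond the scatter) in this assay, a step whose size is only a floor, since compound 3 stands at a limit. Among the compounds with a substituted phenyl on the amine nitrogen, 4-iodophenyl in place of 2-methoxyphenyl gives a 1.9-fold lower number from compound 2 to compound 4 (0.27 log units; within the scatter). Iodo in place of methoxy on an aromatic carbon gives an at least 1.9-fold lower number from compound 1 to compound 4 (0.29 log units; that floor lies within the scatter). Open, as far as these compounds go, is how a benzylamino group on this carbon would compare with (4-iodophenyl)amino, and how a carboxylic acid on the phenyl ring would read.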